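Compound 1 to compound 3: one aromatic group exchanged

The source may report more compounds than this note shows. Statements on the series, on what has been measured and on what is new or still open speak of the compounds shown alone.

Among the compounds with values here, in a physicochemical assay for solubility, read by LC-MS, with a stated time of 16 h, at pH 7 (on this read-out lower numbers stand for lower solubility and higher numbers for higher solubility), compound 1 (`CCCC[S+]([O-])c1sc2nc(-c3nccs3)cc(-c3nccs3)c2c1N`) gives 0.3 ug/mL, the lower of the two numbers so far. Compound 2 (`CCCC[S+]([O-])c1sc2nc(-c3nccn3C)nc(-c3ccccc3)c2c1N`) gives 71 ug/mL, a gap beyond the scatter, though these two compounds differ in more than one place. Compound 3 (`CCCC[S+]([O-])c1sc2nc(-c3nccs3)cc(-c3ccc(CO)cc3)c2c1N`) carries 4-(hydroxymethyl)phenyl in place of 1,3-thiazol-2-yl on an aromatic carbon. Within the data shown here, no measured step isolates this change, so the expectation remains loose. A moderate upward move beyond the scatter is expected, a 5.0-fold higher number from compound 1 to compound 3 (0.70 log units; beyond the scatter). In this assay, the estimate for compound 3 is 1.5 ug/mL, with an expected range of 0.4 ug/mL to 8 ug/mL.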

Compound 3, solubility: 12.5 ug/mL
Compound 3: the middle estimate sits 8.3-fold (0.92 log units) below what was measured, outside the stated range (above it).
By their numbers in this assay, from the lowest: compound 1; then compound 3; then compound 2.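

In this assay, 4-(hydroxymethyl)phenyl in place of 1,3-thiazol-2-yl on this aromatic carbon, opposite the ring nitrogen, gives a 42-fold higher number from compound 1 to compound 3 (1.62 log units; beyond the scatter). Within the data shown here, this is the first step confined to one place, and it shows that the read-out responds strongly to the group at this position while the other 1,3-thiazol-2-yl group stays in place. Nothing at hand bears on the cause of the step.

Open, on these data alone, is how much of the step belongs to the phenyl ring and how much to its hydroxymethyl group. Also open, as far as these compounds go, is how an aminomethyl group or a carboxylic acid in place of that hydroxymethyl group would read.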